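Bromo to trifluoromethyl: a second look at one change

The compounds below may be only part of what the source reports. "The series", "measured", "known", "first", "only" and "open" are said of these compounds alone.

Three compounds have been measured in an assay on isolated protein for inhibition of Indoleamine 2,3-dioxygenase 1 (Homo sapiens), read by spectrophotometry; a lower number here means a stronger inhibitor, a higher number a weaker inhibitor:

Compound 1 `O/N=C(/Nc1cccc(Br)c1)c1ccc2occc2c1` gives 440 nM
Compound 2 `O/N=C(/Nc1cccc(C(F)(F)F)c1)c1ccc2occc2c1` gives 1200 nM
Compound 3 `O/N=C(/Nc1ccc(F)c(Br)c1)c1ccc2occc2c1` gives 1600 nM

Compound 4 `O/N=C(/Nc1ccc(F)c(C(F)(F)F)c1)c1ccc2occc2c1` has not been measured. It differs from compound 3 by trifluoromethyl in place of bromo on an aromatic carbon. The same kind of change separates compound 1 from compound 2, namely (trifluoromethyl in place of bromo on an aromatic carbon), and that step gave a 2.7-fold higher number from compound 1 to compound 2 (0.44 log units; beyond the scatter). The two starting compounds are not the same, since compound 3 differs from compound 1 by fluoro in place of hydrogen on an aromatic carbon; so in compound 3 the bromo that leaves is ortho to a fluoro group (1 heavy atom) as well as meta to a large group, whereas in compound 1 it is only meta to a large group. Going by the values given here, no measured pair shows whether the fluoro group alters the outcome. Among the compounds with values here, the step from compound 3 to compound 4 is therefore expected to be a 2.7-fold higher number from compound 3 to compound 4 (0.43 log units; beyond the scatter), because a 2.7-fold higher number from compound 1 to compound 2 (0.44 log units; beyond the scatter) is the only guide available. Compound 4 is thus estimated at 4300 nM, with an expected range from 2000 nM to 9500 nM.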

Compound 4, half-maximal inhibitory concentration: 1200 nM
Estimate against measurement, compound 4: 3.6-fold (0.55 log units) above; measured number below the stated range.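

On the core carrying the fluoro group, trifluoromethyl in place of bromo gives a 1.3-fold lower number from compound 3 to compound 4 (0.12 log units; within the scatter), so the step seen on the core of compound 1 does not carry over, as the two steps show: the same change on two cores in this assay, a 2.7-fold higher number (0.44 log units; beyond the scatter) from compound 1 to compound 2 and a 1.3-fold lower number (0.12 log units; within the scatter) from compound 3 to compound 4, 3.6-fold (0.56 log units) apart, beyond the scatter of two such steps. Read the other way, adding the fluoro group gives no change at the digits printed from compound 2 to compound 4 (within the scatter), and this step also fails to match its partner: the same change on two cores in this assay, a 3.6-fold higher number (0.56 log units; beyond the scatter) from compound 1 to compound 3 and no change at the digits printed (within the scatter) from compound 2 to compound 4, 3.6-fold (0.56 log units) apart, beyond the scatter of two such steps. In this assay, the size of each step therefore differs with the other group present, but these four compounds do not show why, or whether the same would happen on any other core.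

From the compounds shown here alone, whether chloro, methyl or a nitrile in place of bromo would follow the same course remains open. So does whether a chloro group or an amine in place of the fluoro group would alter the step in the same way.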